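A few compounds are considered here, and "the series" means these few. Any claim that something is new, unique, unknown or untested is made for them only; others in the source may bear on it.

Measured so far:
- compound 1, `CC(C)[C@H](NC(=O)CCN(C)C)c1cccc(F)c1N1CCN(C(=O)[C@@H]2CN(C(C)C)C[C@H]2c2ccc(C(F)(F)F)cc2F)CC1`: 61 nM
- compound 2, `Cc1ccc(N2CCN(C(=O)[C@@H]3CN(C4CCOCC4)C[C@H]3c3ccc(Cl)cc3)CC2)c([C@@H](NC(=O)CN)C(C)C)c1`: 2 nM
- compound 3, `Cc1ccc(N2CCN(C(=O)[C@@H]3CN(C4CCOCC4)C[C@H]3c3ccc(Cl)cc3)CC2)c([C@@H](NC(=O)[C@H](C)N)C(C)C)c1`: 1 nM

In an assay on HEK293 cells for displacement of a labelled ligand from Melanocortin receptor 4 (Homo sapiens) (a lower number here means a stronger inhibitor, a higher number a weaker inhibitor), compound 1 gives the highest of the three numbers; compound 2 and compound 3 lie well below it, both beyond the scatter. Compound 4, `Cc1cccc([C@@H]2CN(C(C)C)C[C@H]2C(=O)N2CCN(c3c(F)cccc3[C@@H](NC(=O)CCN(C)C)C(C)C)CC2)c1`, is not yet measured. It differs from compound 1 in one place: 3-methylphenyl in place of 2-fluoro-4-(trifluoromethyl)phenyl on a saturated ring carbon. Going by the values given here, the only measured step, a 2.0-fold lower number from compound 2 to compound 3 (0.30 log units; within the scatter), lies at a different site of the core and is within the scatter, so it does not bear on this change; compound 2 and compound 3 also differ from compound 1 in more than one place, so no single step covers the aryl exchange. Among the compounds with values here, with no direct precedent, a modest weakening or no shift beyond the scatter is expected: the step of a 1.6-fold higher number from compound 1 to compound 4 (0.21 log units; within the scatter) is the estimate. For compound 4 the expected value is 100 nM, with a range from 30 nM to 400 nM.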

Compound 4, inhibition constant: 470 nM
Estimate against measurement, compound 4: 4.7-fold (0.67 log units) below; the measured number lies above the stated range.
By their numbers in this assay, from the lowest: compounds 3 and 2 (each within the scatter of the next); then compound 1; then compound 4.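

In this assay, the aryl group on the saturated ring carbon of the five-membered ring proves sensitive to exchange: 3-methylphenyl in place of 2-fluoro-4-(trifluoromethyl)phenyl gives a 7.7-fold higher number from compound 1 to compound 4 (0.89 log units; beyond the scatter), the only step shown at this position. The entering group has fewer heavy atoms and no fluorine. Nothing available explains the shift. Open, from the compounds shown here alone, is which part of the exchange carries the step: the fluorine, trifluoromethyl and methyl all change together, and a phenyl bearing only trifluoromethyl or only fluorine would separate them. Also open, going by these compounds, is how a pyridine ring would fare here.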